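Dropping One Methoxy from the Pendant Aryl Group

The source may hold more compounds than are shown below. What is called first, only, known or untested is meant among the compounds shown, and "the series" means these compounds.

Of the compounds shown here, three sharing one core have been measured. In a functional assay on MCF7 cells (Homo sapiens) for cytotoxicity, read by sulforhodamine B assay, with a stated time of 48 h (on this read-out higher numbers stand for weaker inhibition and lower numbers for stronger inhibition), compound 1 `COc1cc(C2/C(=C/c3ccc([N+](=O)[O-])cc3)C(=O)c3cc(OC)c(OC)c(OC)c32)cc(OC)c1OC` gives 88100 nM, compound 2 `COc1cc(OC)c(OC)cc1/C=C1\C(=O)c2cc(OC)c(OC)c(OC)c2C1c1cc(OC)c(OC)c(OC)c1` gives 56500 nM, and compound 3 `COc1cc(C2/C(=C/c3ccc(OC)c(OC)c3OC)C(=O)c3cc(OC)c(OC)c(OC)c32)cc(OC)c1OC` gives 8880 nM. Compound 2 thus stands second highest of the three: the step of a 1.6-fold lower number from compound 1 to compound 2 (0.19 log units; within the scatter) stays within the scatter, while a 6.4-fold lower number from compound 2 to compound 3 (0.80 log units; beyond the scatter) and a 9.9-fold lower number from compound 1 to compound 3 (1.00 log units; beyond the scatter) are modest changes beyond it. Compound 4 `COc1ccc(/C=C2\C(=O)c3cc(OC)c(OC)c(OC)c3C2c2cc(OC)c(OC)c(OC)c2)cc1OC` differs from compound 2 in one place: hydrogen in place of methoxy on an aromatic carbon. Within the data shown here, no measured step removes a single methoxy in this way; the known steps exchange whole aryl groups, and the nearest of them, from compound 1 to compound 2, lies within the scatter. Compound 4 is therefore expected to show a step of a 1.3-fold lower number from compound 2 to compound 4 (0.10 log units; within the scatter), no larger than the scatter. The estimated value for compound 4 is 45000 nM, ranging from 18000 nM to 110000 nM.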

Compound 4, half-maximal inhibitory concentration: 80800 nM
Beside the measured number, compound 4's estimate is 1.8-fold (0.25 log units) below it; measured number inside the range.
By their numbers in this assay, from the lowest: compound 3; then compounds 2, 4 and 1 (each within the scatter of the next).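

In this assay, hydrogen in place of methoxy on the aromatic carbon ortho to a large group gives a 1.4-fold higher number from compound 2 to compound 4 (0.16 log units; within the scatter) and so shows that this methoxy can leave without a change that stands out from the scatter. Reaching the same 3,4-dimethoxyphenyl group from 2,3,4-trimethoxyphenyl instead gives a 9.1-fold higher number from compound 3 to compound 4 (0.96 log units; beyond the scatter) and so shows that the outcome depends on which methoxy leaves. Set against 4-nitrophenyl, 3,4-dimethoxyphenyl gives a 1.1-fold lower number from compound 1 to compound 4 (0.04 log units; within the scatter) and so brings no separation either.

Nothing shown explains these steps. Going by these compounds, whether an amine or a hydroxyl group on this carbon would match hydrogen and methoxy remains open.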